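This account rests on a few compounds, and the source may have more. Where it says the series, first, only, none or still open, it means among the compounds named here.

In a functional assay on MCF7 cells (Homo sapiens) for antiproliferative activity, read by MTT assay, with a stated time of 48 h (on this read-out higher numbers stand for weaker inhibition and lower numbers for stronger inhibition), compound 1 `c1ccc(-c2nn(-c3ccccc3)cc2-c2nc3ccccc3[nH]2)cc1` gives 3190 nM, compound 2 `Cc1ccc2[nH]c(-c3cn(-c4ccccc4)nc3-c3ccccc3)nc2c1` gives 5940 nM and compound 3 `COc1ccc2[nH]c(-c3cn(-c4ccccc4)nc3-c3ccccc3)nc2c1` gives 1590 nM. Compound 2 stands at the top of these numbers only against compound 3, with a 3.7-fold lower number from compound 2 to compound 3 (0.57 log units; beyond the scatter), and it lies within the scatter of compound 1. Compound 4 `Cc1cc2nc(-c3cn(-c4ccccc4)nc3-c3ccccc3)[nH]c2cc1C` differs from compound 2 by methyl in place of hydrogen on an aromatic carbon, ortho to a methyl group. For the measured compounds named here, the nearest precedent is the same kind of replacement, a 1.9-fold higher number from compound 1 to compound 2 (0.27 log units; within the scatter), so no step beyond the scatter is expected in this assay, and any drift is expected to be upward. The expected change is a 1.1-fold higher number from compound 2 to compound 4 (0.04 log units; within the scatter). For compound 4 the estimate is 6500 nM, within an expected range of 2800 nM to 14000 nM.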

Compound 4, half-maximal inhibitory concentration: > 50000 nM
Compound 4 gave a limit, no number; the forecaster's own chance of this, stated with the estimate: 5%; middle value at least 7.6-fold (0.88 log units) from the limit.
By their numbers in this assay, from the lowest: compounds 3, 1 and 2 (each within the scatter of the next, the first and the last beyond it). At a limit, above all of these: compound 4.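

For compound 4 the result in this assay is a limit, > 50000 nM, and not a number. Methyl in place of hydrogen on an aromatic carbon, ortho to a methyl group, gives an at least 8.4-fold higher number from compound 2 to compound 4 (0.92 log units; beyond the scatter), whereas the same kind of replacement with no methyl group ortho to it gave only a 1.9-fold higher number from compound 1 to compound 2 (0.27 log units; within the scatter). So at this position the change can go beyond the scatter, but the step is only a lower bound: the limit of > 50000 nM in this assay, at which 1 of the 4 values shown sits.

On these data alone, whether an amine or a carboxylic acid in this place, ortho to a methyl group, would behave the same way stays open.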